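A Hydroxy Group on the Sulfonyl Chain

The source may hold more compounds than are shown below. What is called first, only, known or untested is meant among the compounds shown, and "the series" means these compounds.

Compound 2 `CCCc1cnc(N2CCC(C3(C)Cc4cc(C5=CCN(S(=O)(=O)CCC)CC5)ccc4O3)CC2)nc1` gives 70 nM in a functional assay on HEK293 cells for agonist activity at Glucose-dependent insulinotropic receptor (Homo sapiens), read by cAMP accumulation, with a stated time of 60 min; a higher number here means that more compound is needed for the effect, a lower number that less compound is needed. Among the three measured compounds it holds the second highest number: the closest is compound 1 `CCCc1cnc(N2CCC(C3Cc4cc(C5=CCN(S(=O)(=O)CCC)CC5)ccc4O3)CC2)nc1`, which gives 82 nM, and the only single-change step known, a 1.2-fold lower number from compound 1 to compound 2 (0.07 log units; within the scatter), came from methyl in place of hydrogen on a saturated ring carbon. The furthest is compound 3 `CCCc1cnc(N2CCC(C3Cc4c(F)c(C5=CCN(S(=O)(=O)CCCO)CC5)cc(F)c4O3)CC2)nc1`, which gives 16 nM in this assay.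

Compound 4 `CCCc1cnc(N2CCC(C3(C)Cc4cc(C5=CCN(S(=O)(=O)CCCO)CC5)ccc4O3)CC2)nc1` differs from compound 2 by hydroxy in place of hydrogen on a saturated chain carbon, three bonds along the chain from a sulfonyl sulfur. Among the measured compounds shown here, no measured pair isolates this change. For the measured compounds named here, the one measured step, a 1.2-fold lower number from compound 1 to compound 2 (0.07 log units; within the scatter), touches a different position and lies within the scatter, so it gives little guidance. Compound 3 carries the same 3-hydroxypropyl chain on the sulfonyl but also two fluorines, and its lower number cannot be split between the two changes. A modest step toward a lower number is therefore expected, a 1.4-fold lower number from compound 2 to compound 4 (0.15 log units; within the scatter), plausibly within the scatter. Compound 4 is estimated at 50 nM, with a range from 20 nM to 120 nM.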

Compound 4, half-maximal effective concentration: 78 nM
Estimate against measurement, compound 4: 1.6-fold (0.19 log units) below, and the stated range covers the measured number.
By their numbers in this assay, from the lowest: compound 3; then compounds 2, 4 and 1 (each within the scatter of the next).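

Among the compounds shown here, this is the only measured pair that isolates the 3-hydroxypropyl chain against the propyl chain on the sulfonyl, and in this assay it reads as a 1.1-fold higher number from compound 2 to compound 4 (0.05 log units; within the scatter). With the methyl on the saturated ring carbon present, hydroxy at this saturated chain carbon therefore produces no readable shift in either direction. No evidence on the cause accompanies these compounds.

From the compounds shown here alone, whether a methoxy group, an amine or a carboxylic acid at the end of this chain, or a longer chain carrying the hydroxy, would read differently remains open. Also open, going by these compounds, are whether hydroxy behaves the same way without the ring methyl, and how much of the number of compound 3 (16 nM) traces to its two fluorines.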